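The source may hold more compounds than are shown below. What is called first, only, known or untested is meant among the compounds shown, and "the series" means these compounds.

Compound 1 `ClCc1ccc(Cn2cnc3c(Cl)ncnc32)cc1`: 1310 nM; compound 2 `ClCc1ccccc1Cn1cnc2c(Cl)nc(Cl)nc21`: 130 nM; compound 3 `ClCc1cccc(Cn2cnc3c(Cl)ncnc32)c1`: 11200 nM.

In a functional assay on DU-145 cells (Homo sapiens) for cytotoxicity, read by sulforhodamine B assay, with a stated time of 48 h (a higher number here means a weaker inhibitor of growth, a lower number a stronger inhibitor of growth), compound 1 gives 1310 nM, the second highest number of the three. Compound 3 gives 11200 nM, a higher number beyond the usual scatter, and compound 2 gives 130 nM, a lower number also beyond the scatter. Among the measured compounds shown here, neither compound 2 nor compound 3 differs from compound 1 in only one place, so no single step can be read from them; the values show only that compound 2, whose core carries a second chloro, has the lowest number of the three.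

Compound 4 `ClCc1ccc(Cn2cnc3c(Cl)nc(Cl)nc32)cc1` is not yet measured. It differs from compound 1 by chloro in place of hydrogen on an aromatic carbon. The step is expected to lower the number by a moderate amount because compound 2 gives 130 nM while also carrying that chloro on its core, although the further difference in compound 2 leaves this uncertain. Compound 4 is therefore estimated at 400 nM, within 100 nM to 1500 nM. The expected step is a 3.3-fold lower number from compound 1 to compound 4 (0.52 log units; beyond the scatter).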

Compound 4, concentration for 50% growth inhibition: 5620 nM
For compound 4 the middle estimate is 14-fold (1.15 log units) below the measured one; measured number above the stated range.
By their numbers in this assay, from the lowest: compound 2; then compound 1; then compounds 4 and 3 (each within the scatter of the next).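

On the carbon between two ring nitrogen atoms, chloro in place of hydrogen makes growth inhibition weaker, not stronger: in this assay the change gives a 4.3-fold higher number from compound 1 to compound 4 (0.63 log units; beyond the scatter) for this pair. Compound 2, which carries the same chloro with its chloromethyl group placed differently, gives 130 nM in this assay, so the chloro does not by itself go with a low number among these compounds. Nothing measured here explains why the number rises with this chloro.

As far as these compounds go, whether an amine or a methoxy group on this same carbon would also raise the number remains open. Among the compounds shown here, also open is whether this chloro would shift compound 3 in the same direction, since only one pair isolates the change.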